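This account rests on a few compounds, and the source may have more. Where it says the series, first, only, none or still open, it means among the compounds named here.

Measured compounds in a functional assay on SK-MEL-2 cells (Homo sapiens) for inhibition, read by sulforhodamine B assay, with a stated time of 48 h; on this read-out lower numbers stand for higher toxicity in this test and higher numbers for lower toxicity in this test:
compound 1, `Nc1cc(N)c2nc(-c3ccccc3)c(Sc3ccc(F)cc3)nc2c1`: < 100000 nM
compound 2, `Nc1cc(N)c2nc(-c3ccccc3)c(Oc3ccc(F)cc3)nc2c1`: < 100000 nM
compound 3, `COc1ccc(CNc2nc3cc(N)cc(N)c3nc2-c2ccccc2)cc1OC`: < 100000 nM

Each of these three values is a limit of the assay, not a number. Compound 1 sits at the limit (the limit of < 100000 nM in this assay, at which 3 of the 3 values shown sit). Compound 2 sits at that same limit. Compound 3 sits at that same limit as well, so its standing among these compounds cannot be read from the numbers. For the measured compounds named here, the one step between measured compounds that differ in a single place, a step that the two limits leave unreadable from compound 1 to compound 2, lies between two limits and so its size is not readable.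

Compound 4, `Nc1cc(N)c2nc(-c3ccccc3)c(NCc3ccc(F)cc3)nc2c1`, differs from compound 3 by the change (4-fluorophenyl in place of 3,4-dimethoxyphenyl on a saturated chain carbon bound to a nitrogen on an aromatic ring). Going by the values given here, no measured step concerns this part of the shared core, and the only measured step, a step that the two limits leave unreadable from compound 1 to compound 2, gives no readable size. Nothing here therefore points to a shift beyond the scatter in either direction, and the most likely outcome is again a limit rather than a number. For compound 4 the estimate is 60000 nM, ranging from 10000 nM to 100000 nM. The estimated step that the limit leaves unreadable from compound 3 to compound 4 is thus expected to be none beyond the scatter.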

Compound 4, concentration lethal to 50% of the cells: < 100000 nM
Compound 4: only a limit was reported; the forecaster's own chance of this, stated with the estimate: 75%; the middle value is on the limit's open side.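

In this assay compound 4 also gives only a limit of the assay, < 100000 nM. Its steps from compound 1, compound 2 and compound 3 therefore cannot be read: the limit of < 100000 nM in this assay, at which 4 of the 4 values shown sit.

On these data alone, whether any of these changes on the shared core alters toxicity in this test stays open.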